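An ethyl extension on the chain of compound 1

The source may report more compounds than this note shows. Statements on the series, on what has been measured and on what is new or still open speak of the compounds shown alone.

Measured in a functional assay on HEL cells (Homo sapiens) for cytotoxicity; on this read-out higher numbers stand for lower toxicity in this test and lower numbers for higher toxicity in this test:
compound 1 `CCCCC#Cc1cc2cn([C@@H]3O[C@H](CO)[C@@H](O)[C@H]3O)c(=O)nc2o1` gives > 144000 nM
compound 2 `CCCCCCCCCCC#Cc1cc2cn(C)c(=O)nc2o1` gives > 150000 nM

Neither entry is a number, since each is a limit of the assay. Going by the values given here, compound 1 therefore has no exact place on the scale, and its only comparison is another limit. Compound 3 `CCCCCCC#Cc1cc2cn([C@@H]3O[C@H](CO)[C@@H](O)[C@H]3O)c(=O)nc2o1` has not yet been measured. It departs from compound 1 by ethyl in place of hydrogen on a saturated chain carbon, four bonds along the chain from a triple-bonded carbon. Among the compounds with values here, no measured step shows what such a change does in this assay. The expectation rests on compound 1, with its limit of > 144000 nM. It rests also on compound 2, whose > 150000 nM is likewise a limit. The expected step of an at least 1.0-fold lower number from compound 1 to compound 3 (0.01 log units; that floor lies within the scatter) stays within the scatter, with no direction foreseen. For compound 3 the estimated value is 140000 nM, with an expected range from 60000 nM to 300000 nM.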

Compound 3, half-maximal cytotoxic concentration: > 133000 nM
Compound 3: a limit, no number (the forecaster's own chance of this, stated with the estimate: 70%); the middle value is on the limit's open side.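

In this assay compound 1 gives > 144000 nM, which is a limit. Going by these compounds alone, compound 3 gives > 133000 nM, also a limit, and no step from compound 1 to compound 3 can be read. The compounds shown leave open what ethyl in place of hydrogen does on this read-out.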